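The source may report more compounds than this note shows. Statements on the series, on what has been measured and on what is new or still open speak of the compounds shown alone.

Three compounds share one core and differ only in a single group attached to an aromatic carbon. Compound 1 `Nc1ccc(S(=O)(=O)N2CCN(c3ncc(C(O)(C(F)(F)F)C(F)(F)F)cc3C#CC3CC3)CC2)cn1` carries a 2-cyclopropylethynyl group, compound 2 `Nc1ccc(S(=O)(=O)N2CCN(c3ncc(C(O)(C(F)(F)F)C(F)(F)F)cc3-c3cnccc3F)CC2)cn1` a 4-fluoropyridin-3-yl group, and compound 3 `COc1cncc(-c2cc(C(O)(C(F)(F)F)C(F)(F)F)cnc2N2CCN(S(=O)(=O)c3ccc(N)nc3)CC2)c1` a 5-methoxypyridin-3-yl group. In an ADME assay (liver) for metabolic stability, with Liver microsome (Homo sapiens) as the target, using microsomes and NADPH, with a stated time of 30 min, tested at 1 uM (a higher number here means faster removal of the compound, a lower number slower removal), compound 1 gives only a limit of the assay, < 14 mL.min-1.g-1. In this assay compound 2 gives 17 mL.min-1.g-1, while compound 3 gives 44 mL.min-1.g-1. Compound 3 therefore holds the highest of the two numbers that were reported, with compound 2 next and compound 1 known only as a limit. The measured steps are a 2.6-fold higher number from compound 2 to compound 3 (0.41 log units; beyond the scatter) and an at least 3.1-fold higher number from compound 1 to compound 3 (0.49 log units; beyond the scatter), so both exchanges leading to the 5-methoxypyridin-3-yl group raised the number.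

Compound 4 `Nc1ccc(S(=O)(=O)N2CCN(c3ncc(C(O)(C(F)(F)F)C(F)(F)F)cc3-c3cc4ccccc4s3)CC2)cn1` has not yet been measured. It differs from compound 3 as follows: 1-benzothiophen-2-yl in place of 5-methoxypyridin-3-yl on an aromatic carbon. Going by the values given here, none of the measured steps involves the 1-benzothiophen-2-yl group, so no direct precedent exists; the steps seen so far run from within the scatter to modest, and the estimate rests on that spread alone. For compound 4 a further modest rise is expected, a 1.5-fold higher number from compound 3 to compound 4 (0.17 log units; within the scatter). Compound 4 is estimated to give 65 mL.min-1.g-1 in this assay, with a range from 25 mL.min-1.g-1 to 160 mL.min-1.g-1.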

Compound 4, intrinsic clearance in microsomes: < 14 mL.min-1.g-1
Compound 4: only a limit was reported (the forecaster's own chance of this, stated with the estimate: 5%); at least 4.6-fold (0.66 log units) between middle value and limit.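

The earlier compounds shown here showed only rises in the number on going to the 5-methoxypyridin-3-yl group, and the change to 1-benzothiophen-2-yl now shows that at this aromatic carbon, ortho to a large group, the number in this assay can also fall, with an at least 3.1-fold lower number from compound 3 to compound 4 (0.49 log units; beyond the scatter). Compound 4 gives < 14 mL.min-1.g-1, which is a limit of the assay and not a number, so this step is a floor and the true size may be larger. Against the 4-fluoropyridin-3-yl group the change gives an at least 1.2-fold lower number from compound 2 to compound 4 (0.08 log units; that floor lies within the scatter), so that floor alone does not separate the two compounds, even though the entering group holds no nitrogen or oxygen and the leaving group does.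

On these data alone, compound 1 and compound 4 cannot be put in order, and the step between them cannot be read, because both rest on the same limit: the limit of < 14 mL.min-1.g-1 in this assay, at which 2 of the 4 values shown sit. Still open is whether a plain thiophene or phenyl group on this carbon would also give so low a reading, which would show whether the sulfur-containing ring, the carbon-only six-membered ring or the two together go with the lower number.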